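This account rests on a few compounds, and the source may have more. Where it says the series, first, only, none or still open, it means among the compounds named here.

Measured so far in a functional assay on HepG2 cells (Homo sapiens) for inhibition, read by MTT assay, with a stated time of 72 h (on this read-out lower numbers stand for stronger inhibition and higher numbers for weaker inhibition), are three compounds:
- compound 1 `CCc1ccc(NC(=O)C2CCN(C/C=C/c3ccccc3)CC2)cc1` gives 23300 nM
- compound 2 `CCCc1ccc(NC(=O)C2CCN(C/C=C/c3ccccc3)CC2)cc1` gives 9410 nM
- compound 3 `CC(C)c1ccc(NC(=O)C2CCN(C/C=C/c3ccccc3)CC2)cc1` gives 12200 nM

Compound 3 does not stand clearly apart from either of the other two, with a 1.9-fold lower number from compound 1 to compound 3 (0.28 log units; within the scatter) and a 1.3-fold higher number from compound 2 to compound 3 (0.11 log units; within the scatter) as its two steps. Compound 4 `CCCCc1ccc(NC(=O)C2CCN(C/C=C/c3ccccc3)CC2)cc1` has not yet been measured. Its difference from compound 3 is butyl in place of isopropyl on an aromatic carbon and the rest of the structure stays the same.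

Within the data shown here, two measured steps bear on this change. The step of a 2.5-fold lower number from compound 1 to compound 2 (0.39 log units; beyond the scatter) is modest, and it is the only one of the three that clears the scatter. The step of a 1.3-fold higher number from compound 2 to compound 3 (0.11 log units; within the scatter) shows that the branched isopropyl and the straight propyl are not separated. Among the measured compounds shown here, no measured compound yet carries a chain as long as butyl, so only a small move towards a lower number is expected.

In this assay the expected change is a 1.5-fold lower number from compound 3 to compound 4 (0.18 log units; within the scatter) and no step beyond the scatter is anticipated. For compound 4 the estimated value is 8000 nM with an expected range from 3500 nM to 17000 nM in this read-out.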

Compound 4, half-maximal inhibitory concentration: 4320 nM
Compound 4: middle estimate off by 1.9-fold (0.27 log units), on the high side; the measured number falls inside the stated range.
By their numbers in this assay, from the lowest: compound 4; then compounds 2, 3 and 1 (each within the scatter of the next, the first and the last beyond it).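

In this assay, butyl stands clearly apart from every other group shown on this aromatic carbon, with a 2.8-fold lower number from compound 3 to compound 4 (0.45 log units; beyond the scatter), a 2.2-fold lower number from compound 2 to compound 4 (0.34 log units; beyond the scatter) and a 5.4-fold lower number from compound 1 to compound 4 (0.73 log units; beyond the scatter). The earlier compounds shown here left propyl and isopropyl unseparated, whereas butyl now separates from both, so across these four compounds the number falls along the straight chains from ethyl through propyl to butyl, while the branched isopropyl does not separate from propyl. A matching change on two cores gave steps that cannot be told apart: the same change on two cores in this assay, a 1.9-fold lower number (0.28 log units; within the scatter) from compound 1 to compound 3 and a 2.2-fold lower number (0.34 log units; beyond the scatter) from compound 2 to compound 4, 1.1-fold (0.06 log units) apart, within the scatter of two such steps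

On these data alone, whether the number keeps falling with a longer chain such as pentyl or hexyl remains open. Also open, as far as these compounds go, is whether a group that is not a plain carbon chain, such as an amine or a carboxylic acid, would fit this trend at this position.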